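Methyl to carbamoyl on the ring nitrogen of compound 2

A few compounds are considered here, and "the series" means these few. Any claim that something is new, unique, unknown or untested is made for them only; others in the source may bear on it.

Of the compounds shown here, two sharing one core have been measured in an assay on isolated protein for inhibition of protein kinase C zeta type (Homo sapiens), with stated times of 1 h and 2.5 min, tested at 30 uM; on this read-out lower numbers stand for less inhibition and higher numbers for more inhibition at the one concentration tested (going by the name of the read-out). Compound 1 `CCOC(=O)c1c(-c2ccc(OC)c(OC)c2)csc1N` gives 100%. Compound 2 `CCOC(=O)c1c(-c2ccc(OC)c(OC)c2)csc1NC`, which carries a methyl in place of hydrogen on a nitrogen on an aromatic ring, gives 32%; on the numbers shown it stands lowest, and the step of a number 68 percentage points lower from compound 1 to compound 2 (beyond the scatter) is large. Compound 3 `CCOC(=O)c1c(-c2ccc(OC)c(OC)c2)csc1NC(N)=O` has not yet been measured. It differs from compound 2 by carbamoyl in place of methyl on a nitrogen on an aromatic ring. Going by the values given here, the only measured step that bears on this change is the one from compound 1 to compound 2, in which adding a methyl to that nitrogen cost heavily; compound 3 removes that methyl again and brings in a group that carries one hydrogen-bond donor and one acceptor, so part of the ground lost may be recovered, though how much the carbamoyl itself costs is unknown from these two compounds. The step from compound 2 to compound 3 is therefore expected to be upward, a number 28 percentage points higher from compound 2 to compound 3 (beyond the scatter). Compound 3 is estimated at 60%, within a range from 25% to 95%.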

Compound 3, a percentage reported as inhibition, at one concentration (the size of the read-out at that concentration, not a potency): 14%
Compound 3: the middle estimate sits 46 percentage points above what was measured; the whole stated range lies above it.
By their numbers in this assay, from the lowest: compound 3; then compound 2; then compound 1.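

In this assay, carbamoyl in place of methyl on a nitrogen on an aromatic ring gives a number 18 percentage points lower from compound 2 to compound 3 (beyond the scatter), so taking the methyl away did not win back what it had cost. Set against the hydrogen on that nitrogen, carbamoyl gives a number 86 percentage points lower from compound 1 to compound 3 (beyond the scatter), a larger fall than methyl gave, which means that among these three compounds both replacements of the hydrogen lower the number and none goes against that. The earlier pair could have pointed to something peculiar to methyl, but the fall now appears with a second group as well, one that carries a hydrogen-bond donor and acceptor where methyl has neither, and no measurement at hand explains it.

The compounds shown leave open whether any group on this nitrogen can keep the number near that of compound 1, and an acetyl, an ethyl or a longer chain there would help to separate the effect of the carbonyl from that of the added carbon. They also leave open how the three compare in potency, since each number comes from one concentration.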